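A few compounds are considered here, and "the series" means these few. Any claim that something is new, unique, unknown or untested is made for them only; others in the source may bear on it.

In a functional assay on HCT-116 cells (Homo sapiens) for antiproliferative activity (on this read-out lower numbers stand for stronger inhibition and higher numbers for weaker inhibition), compound 2 (`Cn1cc(C2=C(c3cn(C)c4ccccc34)C(=O)NC2=O)c2ccccc21`) gives 1440 nM as the higher of the two numbers, and compound 1 (`COc1ccc2c(C3=C(c4c[nH]c5cc(OC)ccc45)C(=O)NC3=O)c[nH]c2c1`) gives 300 nM as the lower, a gap beyond the scatter. Compound 3 (`Cn1cc(C2=C(c3cn(CC(O)CO)c4ccccc34)C(=O)NC2=O)c2ccccc21`) differs from compound 2 by 1,2-dihydroxyethyl in place of hydrogen on a saturated chain carbon bound to an aromatic nitrogen in the form of 1,2-dihydroxyethyl in place of hydrogen on a saturated chain carbon bound to an aromatic nitrogen, which also reads as methyl to 2,3-dihydroxypropyl. Among the compounds with values here, no measured pair shows this change, so the expected 1.1-fold lower number from compound 2 to compound 3 (0.04 log units; within the scatter) stays within the scatter, with no firm direction. The estimated value for compound 3 is 1300 nM (expected range 400 nM to 4500 nM).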

Compound 3, half-maximal inhibitory concentration: 6600 nM
Compound 3: the middle estimate sits 5.1-fold (0.71 log units) below what was measured; measured number above the stated range.
By their numbers in this assay, from the lowest: compound 1; then compound 2; then compound 3.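

At the saturated chain carbon bound to an aromatic nitrogen, placing 1,2-dihydroxyethyl in place of hydrogen in this assay gives a 4.6-fold higher number from compound 2 to compound 3 (0.66 log units; beyond the scatter) as a step beyond the scatter. This position therefore responds to substitution, and this change, also read as methyl to 2,3-dihydroxypropyl, weakens inhibition. Nothing available accounts for the loss. From the compounds shown here alone, whether it belongs to 2,3-dihydroxypropyl specifically or to any larger chain stays open. A propyl chain, or a chain ending in an amine or a carboxylic acid, would separate these readings.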